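Dihalophenyl in place of methoxyphenyl on the carbonyl carbon

The compounds below may be only part of what the source reports. "The series", "measured", "known", "first", "only" and "open" are said of these compounds alone.

Compound 3 `COc1ccc(C(=O)/C=C/c2cc(-c3cc(OC)c(OC)c(OC)c3)n[nH]2)cc1` gives 7600 nM in a functional assay on OVCAR-5 cells (Homo sapiens) for inhibition, read by sulforhodamine B assay, with a stated time of 48 h (a lower number here means that less compound is tolerated, a higher number that more compound is tolerated), the lowest of the two numbers in hand; compound 1 `COc1cc(-c2cc(/C=C/C(=O)c3ccc(N)cc3)[nH]n2)cc(OC)c1OC` gives 7910 nM, and the step of a 1.0-fold lower number from compound 1 to compound 3 (0.02 log units; within the scatter) is within the scatter. Compound 2 `COc1cc(-c2cc(/C=C/C(=O)c3ccc(Cl)c(Cl)c3)[nH]n2)cc(OC)c1OC` returns only a limit, > 100000 nM. Compound 4 `COc1cc(-c2cc(/C=C/C(=O)c3ccc(F)c(F)c3)[nH]n2)cc(OC)c1OC` carries 3,4-difluorophenyl in place of 4-methoxyphenyl on a carbonyl carbon. Within the data shown here, two measured steps bear on this change, an at least 12-fold higher number from compound 1 to compound 2 (1.10 log units; beyond the scatter) and an at least 13-fold lower number from compound 2 to compound 3 (1.11 log units; beyond the scatter), both large and both turning on whether the aryl on the carbonyl carbon is a 3,4-dihalophenyl, the case in which the limit of > 100000 nM in this assay, at which 1 of the 3 values shown sits, was reached. A large upward step in this assay is therefore expected for compound 4, a 7.9-fold higher number from compound 3 to compound 4 (0.90 log units; beyond the scatter). Compound 4 is estimated at 60000 nM, within 15000 nM to 200000 nM, with a real chance that only a limit is returned.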

Compound 4, concentration lethal to 50% of the cells: > 100000 nM
Compound 4: a limit, no number; the forecaster's own chance of this, stated with the estimate: 45%; middle value at least 1.6-fold (0.22 log units) from the limit.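

On the carbonyl carbon, the high number in this assay is not tied to chlorine: 3,4-difluorophenyl gives an at least 13-fold higher number from compound 3 to compound 4 (1.11 log units; beyond the scatter) and an at least 12-fold higher number from compound 1 to compound 4 (1.10 log units; beyond the scatter). Compound 4 returns a limit and not a number, the second such case in the series: the limit of > 100000 nM in this assay, at which 2 of the 4 values shown sit. The step between the two 3,4-dihalophenyl compounds, compound 2 and compound 4, cannot be read, so fluorine and chlorine remain unranked here.

Going by these compounds, whether two halogens are needed stays open. Also open, on these data alone, is how a phenyl carrying a single fluorine, a nitrile or a carboxylic acid would read at this carbonyl carbon.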